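Indole Amide Replaces Fluorophenyl on a Quinoline Amide Core

A few compounds are considered here, and "the series" means these few. Any claim that something is new, unique, unknown or untested is made for them only; others in the source may bear on it.

Compound 1 `CCN1CCN(c2cc(C)c3cc(NC(=O)c4cccc(F)c4)ccc3n2)CC1` was examined in a functional assay on SK-BR-3 cells (Homo sapiens) for antiproliferative activity, read by MTT assay, with a stated time of 72 h (on this read-out lower numbers stand for stronger inhibition and higher numbers for weaker inhibition), and gave 24900 nM. Compound 2 `Cc1cc(N2CCCCC2)nc2ccc(NC(=O)c3ccc(Cl)c(Cl)c3)cc12`, which carries a different amine and a dichlorinated benzamide, gave in this assay a value of 42500 nM. Of the two numbers recorded, compound 1 has the lower one, but its nearest neighbour, compound 2, lies within the usual scatter, so no order between them can be drawn from these two results alone.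

Compound 3 `CCN1CCN(c2cc(C)c3cc(NC(=O)c4cc5ccccc5[nH]4)ccc3n2)CC1` has not been measured in this assay. It differs from compound 1 in one place: 1H-indol-2-yl in place of 3-fluorophenyl on a carbonyl carbon. Within the data shown here, no directly comparable pair among the measured compounds shows how such a change behaves here, so the expectation rests on the shared core alone. The step from compound 1 to compound 3 is expected to be small, at most a modest move toward stronger inhibition, as a 1.7-fold lower number from compound 1 to compound 3 (0.22 log units; within the scatter) indicates. Compound 3 is therefore estimated to give 15000 nM in this assay, within a range of 4000 nM to 60000 nM.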

Compound 3, half-maximal inhibitory concentration: 2550 nM
Compound 3: middle estimate off by 5.9-fold (0.77 log units), on the high side; the measured number lies below the stated range.
By their numbers in this assay, from the lowest: compound 3; then compounds 1 and 2 (each within the scatter of the next).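

In this assay, among these compounds, the change to 1H-indol-2-yl in place of 3-fluorophenyl on a carbonyl carbon brings a 9.8-fold lower number from compound 1 to compound 3 (0.99 log units; beyond the scatter) and so gives the first readable step. Compound 1 and compound 2 differ in both the amine and the benzamide, so they could not show that this place alone can move the value beyond the scatter. The measurements shown offer no explanation for the size of this step.

The compounds shown leave open whether a benzofuran-2-yl group, or a 1-methylindol-2-yl group without the amide-free ring hydrogen, would keep this gain. They also leave open whether the same change would carry over to the different amine of compound 2.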